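This account rests on a few compounds, and the source may have more. Where it says the series, first, only, none or still open, it means among the compounds named here.

Measured compounds:
Compound 1, `O=C1CCC2(c3ccc(F)cc3)OCCCN12`, gives in a functional assay on the whole organism with Mus musculus as the target (a lower number here means that less compound is needed, a higher number that more compound is needed for the effect), a value of 50 mg/kg.
Compound 2, `O=C1CCC2(c3ccccc3)OCCCN12`, gives in this assay a value of 169 mg/kg.

Among the two numbers at hand, compound 2 stands highest; its only neighbour is compound 1, whose number is lower by a step beyond the scatter. Among the measured compounds shown here, the one measured step between them, a 3.4-fold higher number from compound 1 to compound 2 (0.53 log units; beyond the scatter), is the sole piece of evidence that bears on the new compound. Compound 3, `O=C1CCC2(c3ccc(Cl)cc3)OCCCN12`, differs from compound 2 by chloro in place of hydrogen on an aromatic carbon. This is a change at the same place where compound 1 carries its fluoro, and it reintroduces a halogen there. Since removing the fluoro raised the number, as seen in a 3.4-fold higher number from compound 1 to compound 2 (0.53 log units; beyond the scatter), placing a chloro at that spot is expected to move the number back down by a modest step, in the direction of compound 1. The expected step is a 3.4-fold lower number from compound 2 to compound 3 (0.53 log units; beyond the scatter). Compound 3 is therefore estimated to give in this assay about 50 mg/kg, with a range from 20 mg/kg to 130 mg/kg.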

Compound 3, dose for half-maximal effect: 91.7 mg/kg
For compound 3 the middle estimate is 1.8-fold (0.26 log units) below the measured one; the range from low to high includes it.
By their numbers in this assay, from the lowest: compounds 1, 3 and 2 (each within the scatter of the next, the first and the last beyond it).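

In this assay the chloro compound cannot be placed on either side of the earlier gap: chloro in place of hydrogen on this aromatic carbon gives a 1.8-fold lower number from compound 2 to compound 3 (0.27 log units; within the scatter) and chloro in place of fluoro gives a 1.8-fold higher number from compound 1 to compound 3 (0.26 log units; within the scatter), and both steps lie within the scatter. The earlier pair showed only that fluoro and hydrogen at this position can be told apart, with a 3.4-fold higher number from compound 1 to compound 2 (0.53 log units; beyond the scatter) beyond the scatter; compound 3 now shows that a different halogen at the same place gives a value that is separated from neither of them. So the three compounds do not establish a separate effect for chloro, nor do they show that chloro matches fluoro or hydrogen, and no measurement at hand bears on why the values fall as they do.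

The compounds shown leave open how a bromo, a methoxy or an amine would read at this same place on the aromatic ring. They also leave open whether a fluoro or a chloro on another carbon of that ring would give a step beyond the scatter from compound 2 .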